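The source may hold more compounds than are shown below. What is called first, only, known or untested is meant among the compounds shown, and "the series" means these compounds.

Compound 1, `COC(=O)c1ccc(OCCCCOc2ccc(C(=O)CC3CCCC3)c(O)c2C)cc1`, in an assay on HEK293 cells for positive allosteric modulation of metabotropic glutamate receptor 3 (Rattus norvegicus), read by thallium flux, with a stated time of 2.5 min; on this read-out lower numbers stand for an effect already at smaller amounts and higher numbers for an effect only at larger amounts of compound: "not determined" (no result reported).
Compound 2, `Cc1c(OCCCCOc2ccc(C(=O)O)cc2Cl)ccc(C(=O)CC2CCCC2)c1O`, gives > 10000 nM in this assay, which is a limit of the assay and not a number.
Compound 3, `Cc1ccc(C(=O)O)cc1OCCCCOc1ccc(C(=O)CC2CCCC2)c(O)c1C`, gives > 10000 nM in this assay, again a limit of the assay rather than a number.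

Compound 3 therefore stands only at a limit, and of the other two, compound 2 also sits at a limit and compound 1 has no number at all. For the measured compounds named here, the one measured step, a step that the two limits leave unreadable from compound 2 to compound 3, cannot be read because both ends rest on (the limit of > 10000 nM in this assay, at which 2 of the 3 values shown sit). Compound 4, `Cc1c(OCCCCOc2ccc(F)c(C(=O)O)c2)ccc(C(=O)CC2CCCC2)c1O`, differs from compound 3 in one place: 3-carboxy-4-fluorophenyl in place of 5-carboxy-2-methylphenyl on an oxygen on a saturated carbon. Going by the values given here, no measured step bears on this change in a readable way, so nothing beyond the scatter can be predicted for a step that the limit leaves unreadable from compound 3 to compound 4, and a further limit is the most likely outcome. The reason is that compound 3 itself sits at the limit of > 10000 nM in this assay, at which 2 of the 3 values shown sit. Compound 4 is accordingly estimated at 15000 nM, with a range from 4000 nM to 60000 nM.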

Compound 4, half-maximal effective concentration: 2490 nM
For compound 4 the middle estimate is 6.0-fold (0.78 log units) above the measured one, and the stated range ends above it.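

At this place, on an oxygen on a saturated carbon, the substituted ring can lift a compound off the limit in this assay: 3-carboxy-4-fluorophenyl in place of 5-carboxy-2-methylphenyl gives an at least 4.0-fold lower number from compound 3 to compound 4 (0.60 log units; beyond the scatter), and in place of 4-carboxy-2-chlorophenyl it gives an at least 4.0-fold lower number from compound 2 to compound 4 (0.60 log units; beyond the scatter). All three groups carry a carboxy group, so its presence on the ring does not by itself fix the outcome among these compounds. Both steps give only a minimum size, because compound 2 and compound 3 each rest on a limit: the limit of > 10000 nM in this assay, at which 2 of the 4 values shown sit.

The compounds shown do not separate the part played by the fluorine from that of where the carboxy group sits. Also open, going by these compounds, is whether a tetrazole or a primary amide in place of the carboxylic acid, or a longer chain on the oxygen, would keep a readable value.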